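The compounds below may be only part of what the source reports. "The series", "measured", "known", "first", "only" and "open" are said of these compounds alone.

Measured compounds in a functional assay on the whole organism (stomach) with Rattus norvegicus as the target; a higher number here means that more compound is needed for the effect, a lower number that less compound is needed:
Compound 1 `O=C(O)c1ccc(NC(=O)c2ccc(C(=O)O)cc2)cc1`: 54.3 mg/kg
Compound 2 `N#Cc1cccc(C(=O)Nc2cc(C(=O)O)cc(C(=O)O)c2)c1`: 140 mg/kg

Of these two numbers, compound 1 stands lowest in this assay. Among the compounds with values here, compound 2 gives a higher number, and the gap between compound 2 and compound 1 lies beyond the scatter; no single-point step connects the two structures, so the two values are taken only as they stand.

The unmeasured compound 3 `O=C(O)c1ccc(NC(=O)c2ccc(-c3nn[nH]n3)cc2)cc1` differs from compound 1 in one place (2H-tetrazol-5-yl in place of carboxy on an aromatic carbon). Within the data shown here, no step between measured compounds covers this kind of change, so there is no measured precedent in this assay for its size. On the basis of compound 1 alone, the change is expected to move the number little, if at all, with no step beyond the scatter being the most likely outcome, and a somewhat lower number somewhat more likely than a higher one.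

For compound 3, the value in this assay is estimated at 45 mg/kg, with a range from 15 mg/kg to 135 mg/kg. This estimate implies an expected step of a 1.2-fold lower number from compound 1 to compound 3 (0.08 log units; within the scatter).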

Compound 3, dose for 50% inhibition: 3.5 mg/kg
Compound 3: middle estimate off by 13-fold (1.11 log units), on the high side; measured number below the stated range.
By their numbers in this assay, from the lowest: compound 3; then compound 1; then compound 2.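

Putting 2H-tetrazol-5-yl in place of carboxy on this aromatic carbon, para to a large group, gives a 16-fold lower number from compound 1 to compound 3 (1.19 log units; beyond the scatter) in this assay and so counts as a large change. Within the data shown here, this shows that the dose needed is strongly sensitive to the group at this position, something compound 1 and compound 2 could not show, as no single-point step joins them. Nothing measured here accounts for the size of this step.

The compounds shown leave open whether this shift is particular to 2H-tetrazol-5-yl or would also appear with another group at this position, such as a sulfonamide or a hydroxamic acid. They also leave open how the number would respond if the remaining carboxy group of compound 3 gave way to a second 2H-tetrazol-5-yl group.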